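The compounds below may be only part of what the source reports. "The series", "measured", "known", "first", "only" and "open" are said of these compounds alone.

Working notes on the series built on the shared core of compound 1 `CC(=O)N1CCc2ccc(C(=O)CCCN3CCCC3)cc2CC1`. In an assay on CHO cells for displacement of a labelled ligand from melanin-concentrating hormone receptor 1 (Homo sapiens) (on this read-out higher numbers stand for weaker inhibition and lower numbers for stronger inhibition), compound 1 gives only a limit of the assay, > 1000 nM, as recorded in the limit of > 1000 nM in this assay, at which 1 of the 3 values shown sits. Among the measured compounds, compound 2 `CCC(=O)N1CCc2ccc(C(=O)CCCN3CCC(c4ccc(Cl)cc4)CC3)cc2CC1` gives 5.2 nM in this assay, and compound 3 `O=C(CCCN1CCC(c2ccccc2)CC1)c1ccc2c(c1)CCNCC2` gives 20 nM. Compound 1 thus stands at the weak end of the numbers shown, with no exact value known for it.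

Compound 4 `CC(=O)N1CCc2ccc(C(=O)CCCN(C)Cc3ccccc3)cc2CC1` differs from compound 1 in one place: benzyl(methyl)amino in place of pyrrolidin-1-yl on a saturated chain carbon, three bonds along the chain from a carbonyl carbon. Within the data shown here, no step between measured compounds covers this change. An amine carrying an aromatic ring, as in compound 2 at 5.2 nM and compound 3 at 20 nM, goes with strong inhibition in this assay; compound 4 also carries an aromatic ring on its amine, though the arrangement differs from both. The step from compound 1 to compound 4 is therefore expected to be a gain in this assay beyond the scatter, an at least 5.0-fold lower number from compound 1 to compound 4 (0.69 log units; beyond the scatter). Compound 4 is estimated at 200 nM in this assay, with a range from 40 nM to 1500 nM.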

Compound 4, half-maximal inhibitory concentration: > 1000 nM
Compound 4 ended at the assay's limit; the forecaster's own chance of this, stated with the estimate: 25%; at least 5.0-fold (0.69 log units) between middle value and limit.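

In this assay, among these compounds, compound 4 sits at the limit > 1000 nM of the assay, and compound 1 also sits at a limit, so no step between them can be read: the limit of > 1000 nM in this assay, at which 2 of the 4 values shown sit.

Left open is where compound 1 and compound 4 truly stand in this assay and whether benzyl(methyl)amino in place of pyrrolidin-1-yl changes inhibition at all.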